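Thioether benzamide series: cytotoxicity notes toward compound 4

This account rests on a few compounds, and the source may have more. Where it says the series, first, only, none or still open, it means among the compounds named here.

The shared core carries a butanoyloxymethylthio group on the benzamide; the amide substituent varies. Compound 1 `CCCC(=O)OCSc1ccccc1C(=O)NCCCCCCNC(C)=O` bears a chain ending in an acetamide, compound 2 `CCCC(=O)OCSc1ccccc1C(=O)Nc1cccc(C(N)=O)c1` an aryl carboxamide, and compound 3 `CCCC(=O)OCSc1ccccc1C(=O)Nc1ccc(C(N)=O)cc1` the same carboxamide at another position of the aryl ring. In an ADME assay on CEM-SS cells (Homo sapiens) for cytotoxicity, read by XTT assay, with a stated time of 6 days (on this read-out lower numbers stand for higher toxicity in this test and higher numbers for lower toxicity in this test), compound 1 gives 8 uM, compound 2 gives 17.5 uM, and compound 3 gives 39 uM. Compound 1 thus stands at the lowest number of the three, and both other compounds lie beyond the usual scatter above it; no single-point steps among these three are defined.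

Compound 4 `C#CCNC(=O)CNC(=O)c1ccccc1SCOC(=O)CCC` is the next member. Relative to compound 1 the change is propargylcarbamoyl in place of 5-acetamidopentyl on a saturated chain carbon bound to an amide-type nitrogen. Going by the values given here, there is no measured precedent for this kind of change. The step in this assay is expected to be small and, if anything, toward a higher number, since the entering group is the shorter of the two. The estimate for compound 4 is 15 uM, with a range from 5 uM to 45 uM, which means an expected step of a 1.9-fold higher number from compound 1 to compound 4 (0.27 log units; within the scatter).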

Compound 4, half-maximal toxic concentration: 95.4 uM
Compound 4: middle estimate off by 6.4-fold (0.80 log units), on the low side; the measured number lies above the stated range.
By their numbers in this assay, from the lowest: compound 1; then compound 2; then compound 3; then compound 4.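

In this assay, going by these compounds alone, propargylcarbamoyl in place of 5-acetamidopentyl on a saturated chain carbon bound to an amide-type nitrogen gives a 12-fold higher number from compound 1 to compound 4 (1.08 log units; beyond the scatter), the first single-place step, and it is large. The read-out at this position therefore responds strongly to the group carried there, even though the leaving and entering groups match in hydrogen-bond donors and acceptors and neither contains a ring. Nothing measured here accounts for the size of the step.

The compounds shown do not separate the shorter group from the entry of the triple bond, or from the replacement of the terminal acetamide. A propylcarbamoyl group on the same carbon would isolate the triple bond, while a chain ending in an amine or a carboxylic acid would show how far the read-out depends on the chain end.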